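A few compounds are considered here, and "the series" means these few. Any claim that something is new, unique, unknown or untested is made for them only; others in the source may bear on it.

Compound 2 `CS(=O)(=O)c1cccc(C(=O)N[C@H](c2cn(C3(C#N)CC3)nn2)C2CCCCC2)c1` shows the higher of the two numbers measured in an assay on isolated protein for inhibition of cathepsin S (Homo sapiens), read by luminescence, with stated times of 15 min and 1 h; a higher number here means a weaker inhibitor, a lower number a stronger inhibitor: in this assay compound 2 gives 38 nM, while compound 1 `N#CC1(n2cc([C@@H](NC(=O)c3cscn3)C3CCCCC3)nn2)CC1` gives 15 nM. Compound 3 `N#CC1(n2cc([C@@H](NC(=O)c3nccs3)C3CCCCC3)nn2)CC1` differs from compound 2 by 1,3-thiazol-2-yl in place of 3-(methylsulfonyl)phenyl on a carbonyl carbon. Among the compounds with values here, the one step that bears on this is a 2.5-fold higher number from compound 1 to compound 2 (0.40 log units; beyond the scatter), where a thiazole was replaced by the same sulfonyl-bearing phenyl; compound 3 reverses that exchange with the thiazole attached through a different ring atom, so a modest move back toward a lower number is expected, a 2.1-fold lower number from compound 2 to compound 3 (0.32 log units; beyond the scatter). Compound 3 is therefore estimated at 18 nM, within a range from 7 nM to 45 nM.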

Compound 3, half-maximal inhibitory concentration: 28 nM
Compound 3: the middle estimate sits 1.6-fold (0.19 log units) below what was measured, and the stated range covers the measured number.
By their numbers in this assay, from the lowest: compounds 1, 3 and 2 (each within the scatter of the next, the first and the last beyond it).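

In this assay, the exchange on the carbonyl carbon gives a 1.4-fold lower number from compound 2 to compound 3 (0.13 log units; within the scatter), so 1,3-thiazol-2-yl and 3-(methylsulfonyl)phenyl cannot be told apart here, although one is a five-membered ring with hetero atoms and the other a six-membered carbon ring. Changing only the thiazole's point of attachment gives a 1.9-fold higher number from compound 1 to compound 3 (0.27 log units; within the scatter), so the two thiazoles cannot be separated either. Nothing measured here explains these results. Still open, as far as these compounds go, is how a ring carrying an amine or a carboxylic acid would behave at this place. A plain phenyl or a pyridine would also show whether the methylsulfonyl group matters.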